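A Methyl Group on the Ring Carbon Changes Little

This account rests on a few compounds, and the source may have more. Where it says the series, first, only, none or still open, it means among the compounds named here.

Compound 1 `O=C1NC(=O)/C(=C/C2=Cc3cc(Br)ccc3OC2)S1` and compound 2 `O=C1NC(=S)S/C1=C\C1=Cc2cc(Br)ccc2OC1` share most of their framework, but the difference between the two cores is not broken down here. In an ADME assay on NIH3T3 cells (Mus musculus) for antiproliferative activity, read by MTT assay, with a stated time of 72 h (a higher number here means a weaker inhibitor, a lower number a stronger inhibitor), compound 1 gives 56500 nM, while compound 2 gives 27800 nM. Compound 3 `CC1Oc2ccc(Br)cc2C=C1/C=C1\SC(=O)NC1=O` differs from compound 1 by methyl in place of hydrogen on a saturated ring carbon, and in this assay compound 3 gives 56200 nM. The step of a 1.0-fold lower number from compound 1 to compound 3 (0.00 log units; within the scatter) shows that this change left the number essentially unchanged. Compound 4 `CC1Oc2ccc(Br)cc2C=C1/C=C1\SC(=S)NC1=O` is not yet measured; it differs from compound 2 by methyl in place of hydrogen on a saturated ring carbon, the same change in the same place. That change made no difference in a 1.0-fold lower number from compound 1 to compound 3 (0.00 log units; within the scatter), so a similar outcome is expected here. The step expected for compound 4 is a 1.0-fold higher number from compound 2 to compound 4 (0.00 log units; within the scatter). For compound 4 in this assay the estimate is 28000 nM, expected to fall between 14000 nM and 56000 nM.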

Compound 4, half-maximal inhibitory concentration: 28700 nM
The estimate for compound 4 lay 1.0-fold (0.01 log units) below the measured number; low and high end bracket the measured number.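

Methyl in place of hydrogen on a saturated ring carbon again left the number essentially unchanged in this assay, with a 1.0-fold higher number from compound 2 to compound 4 (0.01 log units; within the scatter). On these two cores, the change carried over with the same outcome, as the two steps set side by side show: the same change on two cores in this assay, a 1.0-fold lower number (0.00 log units; within the scatter) from compound 1 to compound 3 and a 1.0-fold higher number (0.01 log units; within the scatter) from compound 2 to compound 4, 1.0-fold (0.02 log units) apart, within the scatter of two such steps. This holds only for these two cores in this one assay; it does not show that the same would happen on any other core, nor does it explain why the number stayed put.

The compounds shown leave open whether a longer chain, an amine or a carboxylic acid on the same ring carbon would also leave the number unchanged. They also leave open how the methyl would behave on a core without the bromine.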